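Swapping the ring on the sulfonyl sulfur: compound 4

This account rests on a few compounds, and the source may have more. Where it says the series, first, only, none or still open, it means among the compounds named here.

Of the compounds shown here, three sharing one core have been measured in an ADME assay on the whole organism (plasma, Rattus norvegicus, strain Sprague-Dawley) for pharmacokinetics, read by LC-MS, using cassette dosing, at a dose of 0.2 mg/kg by the intravenous route; a lower number here means less compound in the circulation, a higher number more compound in the circulation at the dose given. Compound 1 `CNCc1cc(-c2cccnc2F)n(S(=O)(=O)c2cccs2)c1` gives 27 ng.h/mL, compound 2 `CNCc1cn(S(=O)(=O)c2cc(OC)ccn2)c(-c2cccnc2F)c1F` gives 38 ng.h/mL, and compound 3 `CNCc1cn(S(=O)(=O)c2cccnc2C)c(-c2cccnc2F)c1F` gives 32 ng.h/mL. Compound 2 shows the highest of the three numbers, yet its gaps to compound 3 and to compound 1 are both within the usual scatter, so the three cannot be told apart with confidence.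

Compound 4 `CNCc1cn(S(=O)(=O)c2ccc(C)nc2)c(-c2cccnc2F)c1F` is not yet measured. It differs from compound 2 in one place: 6-methylpyridin-3-yl in place of 4-methoxypyridin-2-yl on a sulfonyl sulfur

Going by the values given here, one measured step bears on this change, since it also replaces the 4-methoxypyridin-2-yl group on the sulfonyl sulfur with a different methyl-bearing ring: a 1.2-fold lower number from compound 2 to compound 3 (0.07 log units; within the scatter). That exchange left the number essentially unchanged. By analogy, no step beyond the scatter is expected here either, and the step from compound 2 to compound 4 is estimated as a 1.2-fold lower number from compound 2 to compound 4 (0.06 log units; within the scatter). For compound 4 in this assay the expected value is 33 ng.h/mL, with a likely range from 15 ng.h/mL to 70 ng.h/mL.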

Compound 4, area under the concentration-time curve: 41 ng.h/mL
The estimate for compound 4 lay 1.2-fold (0.09 log units) below the measured number, within the range that was stated.
By their numbers in this assay, from the lowest: compounds 1, 3, 2 and 4 (each within the scatter of the next).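

The new result adds a direct comparison of two methyl-bearing rings on the sulfonyl sulfur: 6-methylpyridin-3-yl in place of 2-methylpyridin-3-yl gives a 1.3-fold higher number from compound 3 to compound 4 (0.11 log units; within the scatter) in this assay. Exchanging 4-methoxypyridin-2-yl for 6-methylpyridin-3-yl, which also removes a hydrogen-bond acceptor by the counts for the two groups, gives a 1.1-fold higher number from compound 2 to compound 4 (0.03 log units; within the scatter). Going by these compounds alone, compounds 2, 3 and 4 thus carry three different six-membered aromatic rings at this position, each with one hetero atom, and no step among them lies beyond the scatter.

Nothing available explains why these exchanges leave the number within the scatter. On these data alone, it also stays open whether a plain phenyl ring, or a ring bearing a carboxylic acid or an amine, would move the number beyond the scatter at this position.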